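Replacing Iodine with a Dimethoxyphenyl Ring on the Amide Aryl

A few compounds are considered here, and "the series" means these few. Any claim that something is new, unique, unknown or untested is made for them only; others in the source may bear on it.

Of the compounds shown here, three sharing one core have been measured in a functional assay on SK-OV-3 cells (Homo sapiens) for antiproliferative activity, read by MTT assay, with a stated time of 72 h; a lower number here means a stronger inhibitor, a higher number a weaker inhibitor. Compound 1 `O=C(CCc1cccc2c1B(O)OC2)Nc1nccs1` gives only a limit there, > 100000 nM. Compound 2 `O=C(CCc1cccc2c1B(O)OC2)Nc1ccc(Cl)cc1` gives 5000 nM, and compound 3 `O=C(CCc1cccc2c1B(O)OC2)Nc1cccc(I)c1` gives 630 nM, the lowest of the two numbers. Every measured step changes the group on the amide-type nitrogen: an at least 20-fold lower number from compound 1 to compound 2 (1.30 log units; beyond the scatter), an at least 150-fold lower number from compound 1 to compound 3 (2.20 log units; beyond the scatter), and a 7.9-fold lower number from compound 2 to compound 3 (0.90 log units; beyond the scatter). Compound 4 `COc1cc(OC)cc(-c2cccc(NC(=O)CCc3cccc4c3B(O)OC4)c2)c1` differs from compound 3 by 3,5-dimethoxyphenyl in place of iodo on an aromatic carbon. Within the data shown here, no measured step swaps a halogen for a second aromatic ring, so the earlier steps only show the scale that aryl changes reach here. Compound 4 is therefore expected to give about 400 nM, within 80 nM to 2500 nM. This expectation amounts to a 1.6-fold lower number from compound 3 to compound 4 (0.20 log units; within the scatter), a small gain that may fall within the scatter.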

Compound 4, half-maximal inhibitory concentration: 44 nM
For compound 4 the middle estimate is 9.1-fold (0.96 log units) above the measured one, outside the stated range (below it).
By their numbers in this assay, from the lowest: compound 4; then compound 3; then compound 2. At a limit, above all of these: compound 1.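

In this assay, the aromatic carbon that held iodo accepts a much larger group: 3,5-dimethoxyphenyl, with 10 heavy atoms in place of 1, gives a 14-fold lower number from compound 3 to compound 4 (1.16 log units; beyond the scatter). The earlier compounds shown here showed only swaps of the whole group on the amide-type nitrogen, whereas this step shows that changing one substituent on the aryl ring also moves the number strongly. Nothing measured here bears on why it does so. Going by these compounds, it remains open whether the added ring alone accounts for the step or the two methoxy groups contribute, and whether an amine or a carboxylic acid on that ring would keep it.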